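A few compounds are considered here, and "the series" means these few. Any claim that something is new, unique, unknown or untested is made for them only; others in the source may bear on it.

Measured so far, in a functional assay on the whole organism (blood, strain Wistar-Okamoto) with Rattus norvegicus as the target, with a stated time of 5 days; on this read-out higher numbers stand for an effect only at larger amounts of compound and lower numbers for an effect already at smaller amounts:

Compound 1, `CCCCC/N=C(\NC#N)Nc1cccnc1`, gives 20 mg/kg.
Compound 2, `CC(C)C/N=C(\NC#N)Nc1cccnc1`, gives 20 mg/kg.

Among the compounds with values here, compound 2 stands level with compound 1: the only measured step, no change at the digits printed from compound 1 to compound 2 (within the scatter), left the dose unchanged within the scatter when one saturated chain was swapped for another on the carbon bound to the double-bonded nitrogen. Compound 3, `N#CN/C(=N\C1CCCC1)Nc1cccnc1`, differs from compound 2 by cyclopentyl in place of isobutyl on a double-bonded nitrogen. Here isobutyl leaves and cyclopentyl enters, a five-membered non-aromatic ring of carbon only, at the same double-bonded nitrogen. Within the data shown here, the one step that bears on this is no change at the digits printed from compound 1 to compound 2 (within the scatter), which shows that changing the saturated group at this position produced no shift beyond the scatter. On that basis no step beyond the scatter is expected in this assay, in either direction. For compound 3 the expected value in this assay is 20 mg/kg, with a range from 8 mg/kg to 50 mg/kg, which means an expected step of no change at the digits printed from compound 2 to compound 3 (within the scatter).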

Compound 3, minimum effective dose: 20 mg/kg
For compound 3 middle estimate and measured number coincide at the digits printed; the measured number falls inside the stated range.
By their numbers in this assay, from the lowest: compounds 1, 2 and 3 (each within the scatter of the next).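

In this assay, cyclopentyl in place of isobutyl on the double-bonded nitrogen gives no change at the digits printed from compound 2 to compound 3 (within the scatter), and cyclopentyl in place of pentyl gives no change at the digits printed from compound 1 to compound 3 (within the scatter). The earlier compounds shown here carried only open chains at this place, whereas compound 3 shows that a five-membered non-aromatic ring of carbon only also leaves the dose level within the scatter. No supporting measurement is available to explain why the dose stays level.

As far as these compounds go, it remains open whether a group carrying atoms other than carbon at this place, such as an amine or a carboxylic acid, would leave the dose level, and the same holds for a much longer chain or a phenyl ring. All three compounds share the same core, so they say nothing about changes made elsewhere in the molecule.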